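Furan-2-yl to Thiophen-2-yl on the Shared Core

The source may hold more compounds than are shown below. What is called first, only, known or untested is meant among the compounds shown, and "the series" means these compounds.

Measured compounds:
compound 1 `COc1ccc(S(=O)(=O)N2CCc3cccc(-c4ccc(N)cc4)c32)cc1` gives 288 nM in a functional assay on NCI-H460 cells (Homo sapiens) for inhibition, with a stated time of 72 h; a higher number here means a weaker inhibitor, a lower number a stronger inhibitor
compound 2 `COc1ccc(S(=O)(=O)N2CCc3cccc(-c4ccco4)c32)cc1` gives 94.5 nM in this assay
compound 3 `COc1ccc(S(=O)(=O)N2CCc3cccc(-c4ccc(O)cc4)c32)cc1` gives 114 nM in this assay

Compound 2 has the lowest number of the three. Its distance from compound 1 is beyond the scatter, a 3.0-fold lower number from compound 1 to compound 2 (0.48 log units; beyond the scatter), but its distance from compound 3 is not, a 1.2-fold higher number from compound 2 to compound 3 (0.08 log units; within the scatter), so compound 2 and compound 3 cannot be ranked against each other. Compound 4 `COc1ccc(S(=O)(=O)N2CCc3cccc(-c4cccs4)c32)cc1` differs from compound 2 in one place: thiophen-2-yl in place of furan-2-yl on an aromatic carbon. For the measured compounds named here, no measured step involves a thiophen-2-yl group. The steps that touch the same place are a 3.0-fold lower number from compound 1 to compound 2 (0.48 log units; beyond the scatter) and a 2.5-fold lower number from compound 1 to compound 3 (0.40 log units; beyond the scatter), both modest, and both arise from a change of donor groups that the present swap does not make; the nearest comparison, a 1.2-fold higher number from compound 2 to compound 3 (0.08 log units; within the scatter), stays within the scatter. A ring of the same size and the same count of hetero atoms is therefore expected to leave the number where compound 2 put it. Compound 4 is expected to give 100 nM in this assay, in the range 45 nM to 230 nM. That estimate means a step of a 1.1-fold higher number from compound 2 to compound 4 (0.02 log units; within the scatter), expected to lie within the scatter.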

Compound 4, half-maximal inhibitory concentration: 229 nM
Compound 4: the middle estimate sits 2.3-fold (0.36 log units) below what was measured; the range from low to high includes it.
By their numbers in this assay, from the lowest: compounds 2, 3, 4 and 1 (each within the scatter of the next, the first and the last beyond it).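

In this assay, this place on the shared core separates two rings that the structural counts match closely: furan-2-yl and thiophen-2-yl are both five-membered aromatic rings with 5 heavy atoms and 1 hetero atom, yet the exchange of oxygen for sulfur gives a 2.4-fold higher number from compound 2 to compound 4 (0.38 log units; beyond the scatter) and is a modest change. A five-membered aromatic ring is therefore not enough on its own to keep a compound level with compound 2, since thiophen-2-yl cannot be told apart from the para-substituted phenyl groups, with a 2.0-fold higher number from compound 3 to compound 4 (0.30 log units; within the scatter) and a 1.3-fold lower number from compound 1 to compound 4 (0.10 log units; within the scatter) as the readings. No measurement of any property of these groups is available to account for the step.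

Still open, going by these compounds, is whether other five-membered rings at this place, such as pyrrol-2-yl or oxazol-2-yl, would stand with compound 2 or with compound 4. Also open, on these data alone, is what a methyl group on the furan-2-yl ring would do.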